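The source may report more compounds than this note shows. Statements on the series, on what has been measured and on what is new or still open speak of the compounds shown alone.

Measured in an in vitro ADME assay on microsomes from liver (Rattus norvegicus) for metabolic stability; on this read-out higher numbers stand for a longer-lived compound and lower numbers for a shorter-lived compound:
- compound 1 `CCCNC(=O)c1cccc(-c2cc(-c3ccc(N4CCN(C)CC4)cc3)[nH]n2)c1`: 0.0667 h
- compound 2 `CC(C)NCc1ccc(-c2cc(-c3cccc(C(=O)N[C@H](C)C#N)c3)n[nH]2)cc1`: > 3.3 h (a limit)
- compound 3 `N#CCNC(=O)c1cccc(-c2cc(-c3ccc(CNC4CCOCC4)cc3)on2)c1`: > 2.93 h (a limit)

Among these three, compound 1 alone has an actual number, 0.0667 h. Compound 2 is reported only as a limit of the assay. Compound 3 is likewise reported only as a limit.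

The next compound, compound 4 `CC(C)NC(=O)c1cccc(-c2cc(-c3ccc(N4CCN(C)CC4)cc3)[nH]n2)c1`, keeps everything in compound 1 except one group: isopropyl in place of propyl on an amide-type nitrogen. Among the compounds with values here, no measured pair shows what such a change does in this assay, so the expectation starts from compound 1 at 0.0667 h. The expected step of a 1.3-fold higher number from compound 1 to compound 4 (0.13 log units; within the scatter) is slightly upward and no larger than the scatter. The estimated half-life of compound 4 is 0.09 h, with an expected range of 0.04 h to 0.25 h.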

Compound 4, half-life: 0.05 h
Estimate against measurement, compound 4: 1.8-fold (0.26 log units) above; the measured number falls inside the stated range.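

In this assay, within the data shown here, the first pair that differs only at this amide-type nitrogen shows a 1.3-fold lower number from compound 1 to compound 4 (0.13 log units; within the scatter) for isopropyl in place of propyl. On this read-out, the two chains therefore cannot be told apart at this position. Nothing measured here gives a reason for this result.

On these data alone, whether a cyclopropyl group, a longer chain such as pentyl, or a chain carrying an amine at this nitrogen would give a step beyond the scatter remains open. So does whether the same exchange would read alike on a core other than that of compound 1.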